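Aryl swaps on the amide nitrogen: the next step

This account rests on a few compounds, and the source may have more. Where it says the series, first, only, none or still open, it means among the compounds named here.

Three compounds with a shared core, differing in the aryl group on the amide-type nitrogen, have been measured in a functional assay on A549 cells (Homo sapiens) for cytotoxicity, read by MTT assay, with a stated time of 72 h; on this read-out lower numbers stand for stronger inhibition and higher numbers for weaker inhibition. Compound 1 `Cc1ccc(NC(=O)CN2CCN(c3nnc(Cc4ccncc4)c4ccccc34)CC2)c(C)c1` gives 45000 nM. Compound 2 `O=C(CN1CCN(c2nnc(Cc3ccncc3)c3ccccc23)CC1)Nc1cccc(Br)c1` gives 1530 nM. Compound 3 `Cc1ccc(F)cc1NC(=O)CN1CCN(c2nnc(Cc3ccncc3)c3ccccc23)CC1` gives 38900 nM, level with compound 1 within the scatter and well above compound 2.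

Compound 4 `O=C(CN1CCN(c2nnc(Cc3ccncc3)c3ccccc23)CC1)Nc1cc(C(F)(F)F)ccc1Cl` carries 2-chloro-5-(trifluoromethyl)phenyl in place of 5-fluoro-2-methylphenyl on the amide-type nitrogen (2-chloro-5-(trifluoromethyl)phenyl in place of 5-fluoro-2-methylphenyl on an amide-type nitrogen).

The measured steps bear on this change only indirectly, since none of them involves the entering group. The step of a 1.2-fold lower number from compound 1 to compound 3 (0.06 log units; within the scatter) shows that one exchange of aryl groups left the number unchanged. The steps of a 29-fold lower number from compound 1 to compound 2 (1.47 log units; beyond the scatter) and a 25-fold higher number from compound 2 to compound 3 (1.41 log units; beyond the scatter) show that the aryl group can also move the number a long way, and both large steps depend on compound 2 alone. The entering group matches neither 3-bromophenyl nor the two groups of the high-value compounds, so three compounds cannot fix the outcome. A moderate shift towards a lower number is expected, smaller than the steps involving compound 2, and the expected step is a 3.2-fold lower number from compound 3 to compound 4 (0.51 log units; beyond the scatter). Compound 4 is estimated at 12000 nM, with an expected range of 2000 nM to 50000 nM.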

Compound 4, half-maximal inhibitory concentration: 1850 nM
Estimate against measurement, compound 4: 6.5-fold (0.81 log units) above, outside the stated range (below it).
By their numbers in this assay, from the lowest: compounds 2 and 4 (each within the scatter of the next); then compounds 3 and 1 (each within the scatter of the next).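

In this assay the exchange of 5-fluoro-2-methylphenyl for 2-chloro-5-(trifluoromethyl)phenyl on the amide-type nitrogen gives a 21-fold lower number from compound 3 to compound 4 (1.32 log units; beyond the scatter) and the corresponding exchange of 2,4-dimethylphenyl gives a 24-fold lower number from compound 1 to compound 4 (1.39 log units; beyond the scatter) so the low numbers at this position no longer rest on compound 2 alone. Two aryl groups that share no substituent now read alike, with a 1.2-fold higher number from compound 2 to compound 4 (0.08 log units; within the scatter) as the step between them, which shows that the low level at this position is not tied to 3-bromophenyl. Across these four compounds, the two aryl groups bearing methyl give the high numbers and the two without methyl give the low numbers; a simple link between halogen and a low number fails, since compound 3 carries fluorine and stays high.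

Still open, from the compounds shown here alone, is whether the chlorine or the trifluoromethyl of the entering group carries the step, and how a plain phenyl, or an aryl group bearing an amine or a carboxylic acid, would read at this position. Whether methyl itself matters also stays open, as no pair here changes methyl alone, and no measurement at hand explains the differences between these aryl groups.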